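The source may hold more compounds than are shown below. What is called first, only, known or untested is meant among the compounds shown, and "the series" means these compounds.

Measured compounds in this series:
- compound 1 `CS(=O)(=O)c1ccc(C(=O)N2CCC(C(=O)N3CCc4ccccc4C3)CC2)cc1[N+](=O)[O-]` — > 60000 nM (a limit of the assay)
- compound 2 `CS(=O)(=O)c1ccc(C(=O)NCCC(=O)N2CCc3ccccc32)cc1[N+](=O)[O-]` — > 60000 nM (a limit of the assay)
- compound 3 `CS(=O)(=O)c1ccc(C(=O)NCC(=O)N2CCCCC2)cc1[N+](=O)[O-]` — > 60000 nM (a limit of the assay)

In an assay on isolated protein for inhibition of vitamin D3 receptor (Homo sapiens), read by fluorescence polarization (on this read-out lower numbers stand for stronger inhibition and higher numbers for weaker inhibition), compound 1 gives only a limit, > 60000 nM. Compound 2 likewise gives only a limit in this assay, > 60000 nM. Compound 3 also stands at a limit in this assay, > 60000 nM. So compound 1 cannot be placed within the set: all three values sit at the limit of > 60000 nM in this assay, at which 3 of the 3 values shown sit, and no step between measured compounds can be read off.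

Compound 4 `CN(Cc1ccccc1)C(=O)C1CCN(C(=O)c2ccc(S(C)(=O)=O)c([N+](=O)[O-])c2)CC1` differs from compound 1 in one place: benzyl(methyl)amino in place of 1,2,3,4-tetrahydroisoquinolin-2-yl on a carbonyl carbon. The change keeps the core of compound 1 and the carbonyl on the saturated ring carbon, exchanging a bicyclic amine for an open benzyl(methyl)amino group of nearly the same size.

Since nothing in the measured set rises above the limit, no step beyond the scatter is expected in this assay; the step from compound 1 to compound 4 is expected to be none, a step that the limit leaves unreadable from compound 1 to compound 4. Compound 4 is therefore expected to give 80000 nM in this assay, within a range of 20000 nM to 300000 nM, most likely again reported only as a limit.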

Compound 4, half-maximal inhibitory concentration: > 60000 nM
Compound 4 was reported as a limit; the forecaster's own chance of this, stated with the estimate: 85%; the middle value is on the limit's open side.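

In this assay compound 4 gives > 60000 nM, a limit of the assay, and compound 1 is also reported only as a limit, so no step can be read between them. The compounds shown leave open which structural change, if any, would give a readable value: the limit of > 60000 nM in this assay, at which 4 of the 4 values shown sit.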